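Benzyl substituent change and tolerated concentration in the series

The source may hold more compounds than are shown below. What is called first, only, known or untested is meant among the compounds shown, and "the series" means these compounds.

Measured so far:
Compound 1 `Cc1cc(/C=C2\SC(=S)N(Cc3ccccc3)C2=O)c(C)n1-c1ccc(O)c(C(=O)O)c1`: 159000 nM
Compound 2 `COc1ccc(CN2C(=O)/C(=C/c3cc(C)n(-c4ccc(O)c(C(=O)O)c4)c3C)SC2=S)cc1`: 75300 nM
Compound 3 `COc1cccc(CN2C(=O)/C(=C/c3cc(C)n(-c4ccc(O)c(C(=O)O)c4)c3C)SC2=S)c1`: 102000 nM

In an ADME assay on MT2 cells (Homo sapiens) for cytotoxicity, read by XTT assay, with a stated time of 4 days (a higher number here means that more compound is tolerated, a lower number that less compound is tolerated), compound 3 stands second highest of the three numbers; its gaps to compound 1 and to compound 2 both lie within the scatter. The steps seen so far all concern a methoxy group: a 2.1-fold lower number from compound 1 to compound 2 (0.32 log units; beyond the scatter) and a 1.6-fold lower number from compound 1 to compound 3 (0.19 log units; within the scatter), while a 1.4-fold higher number from compound 2 to compound 3 (0.13 log units; within the scatter). Compound 4 `COC(=O)c1cccc(CN2C(=O)/C(=C/c3cc(C)n(-c4ccc(O)c(C(=O)O)c4)c3C)SC2=S)c1` differs from compound 3 in one place: methoxycarbonyl in place of methoxy on an aromatic carbon. Among the measured compounds shown here, no measured step replaces a methoxy group by a methoxycarbonyl group, so the expectation rests only on the modest size of the methoxy steps. A step no larger than the scatter is expected, if anything a slightly lower number, a 1.1-fold lower number from compound 3 to compound 4 (0.05 log units; within the scatter). Compound 4 is therefore estimated at 90000 nM, with a range from 45000 nM to 180000 nM.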

Compound 4, half-maximal cytotoxic concentration: 38500 nM
Estimate against measurement, compound 4: 2.3-fold (0.37 log units) above; measured number below the stated range.
By their numbers in this assay, from the lowest: compounds 4, 2, 3 and 1 (each within the scatter of the next, the first and the last beyond it).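

With a methoxycarbonyl group on this aromatic carbon, this assay gives a step beyond the scatter against the methoxy analogue (a 2.6-fold lower number from compound 3 to compound 4 (0.42 log units; beyond the scatter)), so this position is not indifferent to every substituent. Against the unsubstituted benzyl compound the step is larger (a 4.1-fold lower number from compound 1 to compound 4 (0.62 log units; beyond the scatter)), while the comparison with the 4-methoxyphenyl compound stays inside the scatter (a 2.0-fold lower number from compound 2 to compound 4 (0.29 log units; within the scatter)). No measurement available here accounts for the lower number. A carboxylic acid or a primary amide on the same carbon would show whether the lower number is tied to the methoxycarbonyl group as a whole. Going by these compounds, how the methoxycarbonyl group behaves on other carbons of this ring remains open.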